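Hydantoin in place of the chain amide in the series

The source may hold more compounds than are shown below. What is called first, only, known or untested is meant among the compounds shown, and "the series" means these compounds.

Measured so far:
compound 1 `CN(C)[C@H]1C[C@H](c2c[nH]c3ccc(C(N)=O)cc32)C1` — 14.8 nM
compound 2 `CN(C)[C@H]1C[C@H](c2c[nH]c3ccc(CC(N)=O)cc32)C1` — 724 nM

Within the data shown here, compound 2 holds the highest number of the two in an assay on CHO-K1 cells for binding affinity to 5-hydroxytryptamine receptor 1D (Homo sapiens); on this read-out higher numbers stand for weaker inhibition and lower numbers for stronger inhibition; its nearest neighbour, compound 1, differs by a 49-fold higher number from compound 1 to compound 2 (1.69 log units; beyond the scatter), the only measured step, which moves the carbamoyl out by one chain carbon. Compound 3 `CN(C)[C@H]1C[C@H](c2c[nH]c3ccc(CN4C(=O)CNC4=O)cc32)C1` keeps the chain of compound 2 and makes the change (2,5-dioxoimidazolidin-1-yl in place of carbamoyl on a saturated chain carbon bound to an aromatic carbon). Among the measured compounds shown here, no measured step covers a replacement of this kind, so the single step gives only the backdrop: the chain-borne amide of compound 2 sits far above compound 1, and the ring that enters in compound 3 offers a further donor and acceptor in the same place, but nothing measured says how that is read. The expectation for compound 3 is a gain beyond the scatter, a 6.0-fold lower number from compound 2 to compound 3 (0.78 log units; beyond the scatter), with wide uncertainty in both directions. The estimate for compound 3 is 120 nM, within 15 nM to 1000 nM.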

Compound 3, half-maximal inhibitory concentration: 2450 nM
Beside the measured number, compound 3's estimate is 20-fold (1.31 log units) below it, and the stated range ends below it.
By their numbers in this assay, from the lowest: compound 1; then compound 2; then compound 3.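

On the saturated chain carbon bound to an aromatic carbon, the larger ring brings no recovery: in this assay, 2,5-dioxoimidazolidin-1-yl in place of carbamoyl gives a 3.4-fold higher number from compound 2 to compound 3 (0.53 log units; beyond the scatter), a modest step beyond the scatter, despite the added hydrogen-bond acceptor. The distance to the directly attached amide widens further, with a 170-fold higher number from compound 1 to compound 3 (2.22 log units; beyond the scatter), so both chain-borne groups stay well short of the carbamoyl on the aromatic carbon. Nothing available accounts for either step.

The compounds shown do not separate the effect of the ring from that of the added heavy atoms, and they do not show how 2,5-dioxoimidazolidin-1-yl reads directly on the aromatic carbon. On these data alone, it also remains open how a carboxylic acid or an amine on the same chain carbon would read in this assay.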